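This account rests on a few compounds, and the source may have more. Where it says the series, first, only, none or still open, it means among the compounds named here.

Measured so far in a functional assay on K562 cells (Homo sapiens) for inhibition, read by thymidine incorporation, with a stated time of 48 h; a lower number here means a stronger inhibitor, a higher number a weaker inhibitor:
- compound 1, `C(#Cc1[nH]cnc2ncnc1-2)c1ccccc1`: 0.7 ug/mL
- compound 2, `C(#Cc1ncnc2c1ncn2C1CCOCC1)c1ccccc1`: 0.5 ug/mL
- compound 3, `C(#Cc1ncnc2c1ncn2Cc1ccccc1)c1ccccc1`: 1.3 ug/mL

Compound 3 gives the highest of the three numbers in this assay. Its nearest neighbour is compound 1, whose value lies within the usual scatter of that of compound 3, so no order between the two can be claimed. Within the data shown here, the only step among the measured compounds that differs in one place is a 2.6-fold higher number from compound 2 to compound 3 (0.41 log units; beyond the scatter), and it concerns a change on an aromatic nitrogen of the shared core, not the position now in question.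

Compound 4, `Clc1nc(C#Cc2ccccc2)c2ncn(Cc3ccccc3)c2n1`, differs from compound 3 by chloro in place of hydrogen on an aromatic carbon. Among the measured compounds shown here, no measured pair shows the effect of this change; the step from compound 2 to compound 3 bears on a different part of the core and gives no guide here. With nothing in the series to point either way, the expectation for this assay is a step of no change at the digits printed from compound 3 to compound 4 (within the scatter), that is, no change beyond the scatter. Compound 4 is therefore estimated at 1.3 ug/mL, with a range from 0.45 ug/mL to 3.8 ug/mL.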

Compound 4, half-maximal inhibitory concentration: 0.12 ug/mL
For compound 4 the middle estimate is 11-fold (1.03 log units) above the measured one; the whole stated range lies above it.
By their numbers in this assay, from the lowest: compound 4; then compounds 2, 1 and 3 (each within the scatter of the next, the first and the last beyond it).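

In this assay, among these compounds, chloro in place of hydrogen on the aromatic carbon between two ring nitrogen atoms gives an 11-fold lower number from compound 3 to compound 4 (1.03 log units; beyond the scatter) and is the first sign that this position of the shared core can move the read-out. Among the compounds shown here, until now, the only readable single change lay on an aromatic nitrogen, so this step shows that adding one chlorine atom to a ring carbon is enough for a large effect with the benzyl group and the 2-phenylethynyl group in place. No available evidence accounts for the step.

On these data alone, it remains open whether this step is particular to chloro or would also appear with an amine or a methoxy group on the same carbon. As far as these compounds go, it also remains open whether chloro gives a similar step with oxan-4-yl on the aromatic nitrogen, as in compound 2.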